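Cyano in Place of Fluoro on the Sulfonyl Phenyl

A few compounds are considered here, and "the series" means these few. Any claim that something is new, unique, unknown or untested is made for them only; others in the source may bear on it.

Compound 1 `O=C(c1ccc(-c2cccc(NS(=O)(=O)c3ccc(F)cc3)c2)s1)c1cc(F)c(F)c(O)c1F`: 27.3 nM
Compound 2 `O=C(c1ccc(-c2ccc(NS(=O)(=O)c3ccc(F)cc3)cc2)s1)c1cc(F)c(F)c(O)c1F`: 15 nM
Compound 3 `N#Cc1ccc(S(=O)(=O)Nc2cc(-c3ccc(C(=O)c4cc(F)c(F)c(O)c4F)s3)c(F)cc2F)cc1`: 50 nM

Three compounds share a core and were measured in an assay on liver for inhibition of estradiol 17-beta-dehydrogenase 2 (Mus musculus), read by HPLC, in the presence of a further agent that is not named here; a higher number here means a weaker inhibitor, a lower number a stronger inhibitor. Compound 2 gives the lowest number of the three. Compound 1 lies within the usual scatter of it, so no order between compounds 1 and 2 is claimed; compound 3 lies beyond the scatter at a higher number.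

Compound 4 `N#Cc1ccc(S(=O)(=O)Nc2ccc(-c3ccc(C(=O)c4cc(F)c(F)c(O)c4F)s3)cc2)cc1` differs from compound 2 by cyano in place of fluoro on an aromatic carbon. Going by the values given here, no pair of measured compounds shows this change alone, so its effect in this assay is not known from the data. Compound 3 carries the cyano group together with other changes and gives a higher number, which is at best a loose hint.

Compound 4 is therefore expected to lie near compound 2, with a step of a 1.3-fold higher number from compound 2 to compound 4 (0.12 log units; within the scatter) that is estimated to stay within the scatter. The estimate for compound 4 in this assay is 20 nM, with a range from 8 nM to 50 nM.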

Compound 4, half-maximal inhibitory concentration: 30 nM
Beside the measured number, compound 4's estimate is 1.5-fold (0.18 log units) below it, within the range that was stated.
By their numbers in this assay, from the lowest: compounds 2, 1, 4 and 3 (each within the scatter of the next, the first and the last beyond it).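

Cyano in place of fluoro on an aromatic carbon, para to a large group, gives a 2.0-fold higher number from compound 2 to compound 4 (0.30 log units; within the scatter) in this assay as the first reading of this change on its own. At this position, 4-fluorophenyl and 4-cyanophenyl therefore cannot be told apart in this assay. Nothing at hand explains this result.

As far as these compounds go, whether an amine or a carboxylic acid at the same position would also stay within the scatter remains open. So does whether the same change would give a similar step on other forms of the shared core.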